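Methoxy to chloro at a cytotoxicity ceiling

The source may hold more compounds than are shown below. What is called first, only, known or untested is meant among the compounds shown, and "the series" means these compounds.

Compound 1 `O=C(/C=C\c1ccc([N+](=O)[O-])cc1)N1N=C(c2ccncc2)OC1c1c[nH]c2ccccc12` was tested in an ADME assay on PANC-1 cells (Homo sapiens) for cytotoxicity, read by MTT assay, with a stated time of 48 h; a lower number here means a stronger inhibitor of growth, a higher number a weaker inhibitor of growth. In this assay compound 1 reaches only the limit > 30 ug/mL. Compound 2 `COc1ccc(/C=C\C(=O)N2N=C(c3ccncc3)OC2c2c[nH]c3ccccc23)cc1` likewise gives only the limit > 30 ug/mL. The step that the two limits leave unreadable from compound 1 to compound 2 is therefore unreadable, since both rest at the limit of > 30 ug/mL in this assay, at which 2 of the 2 values shown sit. Compound 3 `O=C(/C=C\c1cccc(Cl)c1)N1N=C(c2ccncc2)OC1c1c[nH]c2ccccc12` differs from compound 2 by 3-chlorophenyl in place of 4-methoxyphenyl on a double-bonded chain carbon bound to a double-bonded chain carbon. Within the data shown here, no measured step bears on this change, and with both neighbours at the ceiling no direction can be read from the numbers. Compound 3 is expected to sit near the same ceiling, with 40 ug/mL (12 ug/mL to 130 ug/mL) as the estimate. The expected step that the limit leaves unreadable from compound 2 to compound 3 is hence no change beyond the scatter.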

Compound 3, concentration for 50% growth inhibition: > 30 ug/mL
Compound 3 gave a limit, no number (the forecaster's own chance of this, stated with the estimate: 70%); the middle value does not contradict the limit.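

Compound 3 also stops at a limit, so no step among compound 1, compound 2 and compound 3 can be read: the limit of > 30 ug/mL in this assay, at which 3 of the 3 values shown sit.

The compounds shown leave open whether 4-nitrophenyl, 4-methoxyphenyl and 3-chlorophenyl differ at all in this assay, with no compound here giving a number.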